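Hydroxy in place of benzyl at the quaternary ring carbon

A few compounds are considered here, and "the series" means these few. Any claim that something is new, unique, unknown or untested is made for them only; others in the source may bear on it.

Measured so far:
compound 1 `CC(=O)O[C@@H]1OC(=O)[C@](O)(C(C)=O)[C@@H]1C` > 50000 nM
compound 2 `CC(=O)O[C@@H]1OC(=O)[C@@](C)(C(C)=O)[C@@H]1C` 12000 nM
compound 3 `CC(=O)O[C@@H]1OC(=O)[C@@](Cc2ccccc2)(C(C)=O)[C@@H]1C` 39000 nM

In a functional assay on HT-29 cells (Homo sapiens) for cytotoxicity, read by MTT assay (a lower number here means a stronger inhibitor, a higher number a weaker inhibitor), compound 2 gives 12000 nM and compound 3 gives 39000 nM. For compound 1 the value > 50000 nM is a limit of the assay, not a number (the limit of > 50000 nM in this assay, at which 1 of the 3 values shown sits). Among the two numbers shown, compound 3 has the highest; the nearest is compound 2, and the step of a 3.3-fold higher number from compound 2 to compound 3 (0.51 log units; beyond the scatter) runs beyond the scatter.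

Compound 4 `CC(=O)O[C@@H]1OC(=O)[C@@](O)(C(C)=O)[C@@H]1C` is not yet measured. It differs from compound 3 by hydroxy in place of benzyl on a saturated ring carbon. Among the compounds with values here, only one measured step touches this position, a 3.3-fold higher number from compound 2 to compound 3 (0.51 log units; beyond the scatter), and it concerns benzyl against hydrogen, not hydroxy. Compound 1 carries hydroxy at the same carbon in the other configuration and sits at the limit of this assay. The data give no step for hydroxy against benzyl, so the direction rests on the weak showing of compound 1 and on compound 3 already being the highest number shown.

For compound 4 the number in this assay is expected to stay near the top of the series or beyond it, as a step of a 1.2-fold higher number from compound 3 to compound 4 (0.06 log units; within the scatter) within the scatter, with a good chance that only a limit is reported. The estimate for compound 4 is 45000 nM, ranging from 15000 nM to 150000 nM.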

Compound 4, half-maximal inhibitory concentration: > 50000 nM
Compound 4: only a limit was reported (the forecaster's own chance of this, stated with the estimate: 50%); middle value at least 1.1-fold (0.04 log units) away from the limit.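

In this assay, hydroxy at this saturated ring carbon now stands at a limit of the assay in both drawn configurations: the limit of > 50000 nM in this assay, at which 2 of the 4 values shown sit. Replacing methyl by hydroxy gives an at least 4.1-fold higher number from compound 2 to compound 4 (0.61 log units; beyond the scatter), a floor that already lies beyond the scatter, whereas replacing benzyl by hydroxy gives an at least 1.2-fold higher number from compound 3 to compound 4 (0.10 log units; that floor lies within the scatter), a floor within the scatter that sets no order between those two groups. The step between the two hydroxy compounds cannot be read, so no effect of configuration at this carbon can be stated for the pair: the fact that compounds 1 and 4 differ only in the configuration as drawn.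

On these data alone, how far past the limit the two hydroxy compounds lie remains open, as does any effect of configuration at this carbon when methyl or benzyl occupies it. Also open, as far as these compounds go, is how an amine, a carboxylic acid or a longer chain at this carbon would compare with methyl and benzyl in this assay.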